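Aryl swap on an aromatic nitrogen in an inactive series

The source may report more compounds than this note shows. Statements on the series, on what has been measured and on what is new or still open speak of the compounds shown alone.

Of the compounds shown here, two of the shared core have been measured. Compound 1 `N#CC1=C(N)Oc2c(c3nc4ccccc4nc3c3ccccc23)C12C(=O)N(Cc1cnnn1-c1ccc(Cl)cc1)c1ccccc12` carries a 4-chlorophenyl on an aromatic nitrogen. In a functional assay on A549 cells (Homo sapiens) for antiproliferative activity, read by MTT assay, with a stated time of 48 h (a lower number here means a stronger inhibitor, a higher number a weaker inhibitor), compound 1 gives only a limit, > 50000 nM. Compound 2 `N#CC1=C(N)Oc2c(c3nc4ccccc4nc3c3ccccc23)C12C(=O)N(Cc1cnnn1-c1cccc(Br)c1)c1ccccc12` carries a 3-bromophenyl in place of it. In this assay compound 2 likewise gives only a limit, > 50000 nM. The step that the two limits leave unreadable from compound 1 to compound 2 cannot be read, as both ends are limits; the limit of > 50000 nM in this assay, at which 2 of the 2 values shown sit, marks where the whole series stands so far. Compound 3 `COc1ccccc1-n1nncc1CN1C(=O)C2(C(C#N)=C(N)Oc3c2c2nc4ccccc4nc2c2ccccc32)c2ccccc21` is not yet measured; it differs from compound 2 by 2-methoxyphenyl in place of 3-bromophenyl on an aromatic nitrogen. Only the unreadable step from compound 1 to compound 2 bears on this change, so no direction beyond the scatter can be argued, and a further limit is the expectation. Compound 3 is therefore expected to give about 70000 nM in this assay, most probably reported again as a limit, within 20000 nM to 300000 nM. The expected step that the limit leaves unreadable from compound 2 to compound 3 is estimated as none beyond the scatter.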

Compound 3, half-maximal inhibitory concentration: > 50000 nM
Compound 3: no number, only a limit; the forecaster's own chance of this, stated with the estimate: 85%; the middle value is on the limit's open side.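

Neither the step from compound 2 to compound 3 nor that from compound 1 to compound 3 can be read in this assay, as every end is a limit: the limit of > 50000 nM in this assay, at which 3 of the 3 values shown sit.

The compounds shown leave open whether any aryl group at this aromatic nitrogen of the shared core gives a measurable value in this assay, and how 4-chlorophenyl, 3-bromophenyl and 2-methoxyphenyl compare.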